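Chloro-to-methyl swaps on a tosylate-acrylamide thiadiazole series

The compounds below may be only part of what the source reports. "The series", "measured", "known", "first", "only" and "open" are said of these compounds alone.

Three members of this series have been measured in an ADME assay on HEK-293T cells (Homo sapiens) for inhibition, read by CCK-8 assay, with a stated time of 48 h, tested at 20 uM; on this read-out lower numbers stand for less inhibition of growth and higher numbers for more inhibition of growth at the one concentration tested. Compound 1 `Cc1ccc(S(=O)(=O)Oc2ccccc2/C=C(\C#N)C(=O)Nc2nnc(Cc3ccccc3)s2)cc1` gives 15%. Compound 2 `N#C/C(=C\c1ccccc1OS(=O)(=O)c1ccc(Cl)cc1)C(=O)Nc1nnc(Cc2ccccc2)s1` gives 25%. Compound 3 `Cc1ccc(S(=O)(=O)Oc2ccccc2/C=C(\C#N)C(=O)Nc2nnc(Cc3ccc(Cl)cc3)s2)cc1` gives 20%. The step of a number 10 percentage points lower from compound 2 to compound 1 (within the scatter) rests on the change (methyl in place of chloro on an aromatic carbon). The step of a number 5 percentage points higher from compound 1 to compound 3 (within the scatter) leaves compound 3 and compound 1 within the scatter of each other, and the same holds for compound 3 against compound 2; the difference between the cores of compound 3 and compound 2 is not broken down here.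

Compound 4 `Cc1ccc(Cc2nnc(NC(=O)/C(C#N)=C/c3ccccc3OS(=O)(=O)c3ccc(C)cc3)s2)cc1` is not yet measured in this assay. It differs from compound 3 by methyl in place of chloro on an aromatic carbon. This is the same change already made from compound 2 to compound 1, though cut one bond further out it reads 4-chlorobenzyl to 4-methylbenzyl rather than (4-chlorophenyl)sulfonyl to (4-methylphenyl)sulfonyl. Since that earlier step stayed within the scatter, the step from compound 3 to compound 4 is expected to be a number 5 percentage points lower from compound 3 to compound 4 (within the scatter), of similar small size. For compound 4 in this assay the estimate is 15%, with a range from 5% to 28%.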

Compound 4, percent growth inhibition at one concentration: 22%
Compound 4: middle estimate off by 7 percentage points, on the low side; measured number inside the range.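

Methyl in place of chloro on the 4-chlorobenzyl core reads in this assay as a number 2 percentage points higher from compound 3 to compound 4 (within the scatter), and the hydrogen-to-methyl change reads as a number 7 percentage points higher from compound 1 to compound 4 (within the scatter). Set side by side, the two instances of the chloro-to-methyl change do not separate on this read-out: the same change on two cores in this assay, a number 10 percentage points lower (within the scatter) from compound 2 to compound 1 and a number 2 percentage points higher (within the scatter) from compound 3 to compound 4, 12 percentage points apart, within the scatter of two such steps. This shows that the change has so far been carried between two cores without a step beyond the scatter in either; it does not show that the change is without effect, gives it no direction, and two cores cannot speak for the whole series.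

The compounds shown leave open how groups other than chloro, methyl and hydrogen would read on these aromatic carbons, for example a methoxy group, an amine or a carboxylic acid. Also open, going by these compounds, is whether a longer chain in place of the benzyl methylene would move the number beyond the scatter.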